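A few compounds are considered here, and "the series" means these few. Any claim that something is new, unique, unknown or untested is made for them only; others in the source may bear on it.

Compound 1 `COc1ncnc2c1c(-c1ccsc1)cn2[C@@H]1O[C@H](CO)[C@@H](O)[C@H]1O` gives 7640 nM in a functional assay on CEM-DNR-bulk cells (Homo sapiens), read by MTT assay, with a stated time of 72 h; on this read-out higher numbers stand for weaker inhibition and lower numbers for stronger inhibition; it is the only numerical result in the set. Compound 2 `COc1nc(N)nc2c1c(-c1ccsc1)cn2[C@@H]1O[C@H](CO)[C@@H](O)[C@H]1O` reports only a limit, > 20000 nM, in this assay. Among the compounds with values here, the step of an at least 2.6-fold higher number from compound 1 to compound 2 (0.41 log units; beyond the scatter) is the one measured change, and it ends at the limit of > 20000 nM in this assay, at which 1 of the 2 values shown sits. Compound 3 `CNc1ncnc2c1c(-c1ccsc1)cn2[C@@H]1O[C@H](CO)[C@@H](O)[C@H]1O` differs from compound 1 by methylamino in place of methoxy on an aromatic carbon. The measured step concerns a different place and a different group, so it bears only loosely on this change; no step beyond the scatter is expected for compound 3, a 1.3-fold higher number from compound 1 to compound 3 (0.12 log units; within the scatter). Compound 3 is estimated at 10000 nM in this assay, within 3000 nM to 30000 nM.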

Compound 3, half-maximal inhibitory concentration: > 20000 nM
Compound 3: no number, only a limit (the forecaster's own chance of this, stated with the estimate: 35%); middle value at least 2.0-fold (0.30 log units) away from the limit.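

Methylamino in place of methoxy on this aromatic carbon gives an at least 2.6-fold higher number from compound 1 to compound 3 (0.41 log units; beyond the scatter) in this assay. Within the data shown here, the earlier step concerned a different place, so this is the first sign that the methoxy-bearing carbon also tolerates exchange poorly in this assay. Compound 3 carries a limit, not a number, so the full size of the step stays unknown: the limit of > 20000 nM in this assay, at which 2 of the 3 values shown sit.

Among these compounds, only one group at this place has a numerical result so far, with compound 1 at 7640 nM. From the compounds shown here alone, whether ethoxy, dimethylamino or a plain methyl group here would stay close to compound 1 remains open.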